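The compounds below may be only part of what the source reports. "The series", "measured", "known", "first", "only" and "open" are said of these compounds alone.

The measured compounds and their values in a functional assay on MCF7 cells (Homo sapiens) for cytotoxicity, read by MTT assay, with a stated time of 72 h; a higher number here means a weaker inhibitor, a lower number a stronger inhibitor:
Compound 1, `Cc1ccc(-c2ccc(F)cc2)n1-c1ccc(-c2nc3ccc(F)cc3s2)cc1`, gives 2800 nM.
Compound 2, `COc1ccc2nc(-c3ccc(-n4c(C)ccc4-c4ccc(F)cc4)cc3)sc2c1`, gives 2800 nM.
Compound 3, `COc1cc2nc(-c3ccc(-n4c(C)ccc4-c4ccc(F)cc4)cc3)sc2c(OC)c1OC`, gives 2910 nM.

All three compounds slow the growth of these cancer cells at much the same concentration, and none of the gaps between them is large enough to count. Compound 1 and compound 2 differ in one spot only: methoxy in place of fluoro on an aromatic carbon. That exchange made a step of no change at the digits printed from compound 1 to compound 2 (within the scatter). Compound 3 carries a different core from compound 1; the difference between the two cores is not broken down here.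

Compound 4, `COc1ccc(-c2ccc(C)n2-c2ccc(-c3nc4cc(OC)c(OC)c(OC)c4s3)cc2)cc1`, has not been measured. It comes from compound 3 by methoxy in place of fluoro on an aromatic carbon. Among the compounds with values here, this is the same kind of change as the one from compound 1 to compound 2, not the same one: in compound 2 the new group sits on a ring that is part of a fused system of two rings, meta to a fused ring and para to a fused ring, whereas in compound 4 it sits on a six-membered aromatic ring of carbon only, para to a large group. Within the data shown here, still, the one measured example points to a small step, because no change at the digits printed from compound 1 to compound 2 (within the scatter) was seen for compound 1 and compound 2. The expected outcome is a step of a 1.0-fold lower number from compound 3 to compound 4 (0.00 log units; within the scatter). For compound 4 in this assay the estimate is 2900 nM, with a likely range from 1400 nM to 6000 nM.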

Compound 4, half-maximal inhibitory concentration: 2200 nM
Estimate against measurement, compound 4: 1.3-fold (0.12 log units) above; the range from low to high includes it.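

In this assay, exchanging fluoro for methoxy, which turns a 4-fluorophenyl group into a 4-methoxyphenyl group, gave a 1.3-fold lower number from compound 3 to compound 4 (0.12 log units; within the scatter). Set beside the earlier example of this exchange, the new result agrees with it, and the two cores give no measurable difference in how the change plays out: the same change on two cores in this assay, no change at the digits printed (within the scatter) from compound 1 to compound 2 and a 1.3-fold lower number (0.12 log units; within the scatter) from compound 3 to compound 4, 1.3-fold (0.12 log units) apart, within the scatter of two such steps. Within the data shown here, this shows that in these two pairs, methoxy can stand in for fluoro without a readable shift in the cell result, but it does not show that the exchange would be this quiet on every core, since there are only two examples, the new group sits in a different place in each, and neither step rises above the scatter.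

The compounds shown leave open whether any other group on this aromatic carbon, such as an amine, a carboxylic acid or a longer chain like butoxy, would move the number beyond the scatter. They also leave open whether this exchange would stay as small in a cell line other than the one tested here.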